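Antiproliferative screen of a spirocyclic series: limits only so far

The source may report more compounds than this note shows. Statements on the series, on what has been measured and on what is new or still open speak of the compounds shown alone.

compound 1 `N#CC1=C(N)Oc2c(c3nc4ccccc4nc3c3ccccc23)C12C(=O)N(Cc1cnnn1-c1ccc(Cl)cc1)c1ccccc12`: in a functional assay on MCF7 cells (Homo sapiens) for antiproliferative activity, read by MTT assay, with a stated time of 48 h (on this read-out higher numbers stand for weaker inhibition and lower numbers for stronger inhibition), compound 1 reaches only the assay limit, > 50000 nM
compound 2 `Cc1cc(C)cc(-n2nncc2CN2C(=O)C3(C(C#N)=C(N)Oc4c3c3nc5ccccc5nc3c3ccccc43)c3ccccc32)c1`: compound 2 likewise sits at the assay limit, > 50000 nM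
compound 3 `Cc1ccccc1-n1nncc1CN1C(=O)C2(C(C#N)=C(N)Oc3c(N)cc4nc5ccccc5nc4c32)c2ccccc21`: compound 3 too is reported only as the assay limit, > 50000 nM

Compound 3 stands where the whole set stands: at the limit rather than at a number, as the limit of > 50000 nM in this assay, at which 3 of the 3 values shown sit, records for every value shown. Among the compounds with values here, the one change that can be compared between measured compounds, from compound 1 to compound 2, is a step that the two limits leave unreadable from compound 1 to compound 2, so it says nothing about the size of a swap on the aromatic nitrogen of the five-membered aromatic ring with three nitrogens.

Compound 4 `Cc1ccc(-n2nncc2CN2C(=O)C3(C(C#N)=C(N)Oc4c(N)cc5nc6ccccc6nc5c43)c3ccccc32)cc1C` differs from compound 3 by 3,4-dimethylphenyl in place of 2-methylphenyl on an aromatic nitrogen. No readable step bears on this change; the only related one is the unreadable step just named. With every value at the limit, compound 4 is expected to remain there as well, and the step that the limit leaves unreadable from compound 3 to compound 4 is estimated to be none beyond the scatter. For compound 4 the estimate in this assay is 60000 nM, in a range from 30000 nM to 200000 nM.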

Compound 4, half-maximal inhibitory concentration: > 50000 nM
Compound 4: a limit, no number; the forecaster's own chance of this, stated with the estimate: 85%; the middle value does not contradict the limit.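

Compound 4, like compound 3, gives only a limit in this assay, so no new step can be read between them: the limit of > 50000 nM in this assay, at which 4 of the 4 values shown sit.

The compounds shown leave open how large any swap on the aromatic nitrogen is, and whether any member of the series gives a number rather than a limit.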